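The source may hold more compounds than are shown below. What is called first, only, known or untested is meant among the compounds shown, and "the series" means these compounds.

In an ADME assay on Raji cells (Homo sapiens) for cytotoxicity, with a stated time of 72 h (a higher number here means that more compound is needed for the effect, a lower number that less compound is needed), compound 1 `O=C(Nc1ccc(F)c(-c2nc3ccccc3o2)c1)c1cc([N+](=O)[O-])ccc1Cl` gives > 25000 nM as a limit of the assay and not a number. Compound 3 `Cc1cc(NC(=O)c2cc([N+](=O)[O-])ccc2Cl)cc(-c2nc3ccccc3o2)c1O` gives > 25000 nM as a limit too. Compound 2 `O=C(Nc1nc2c(Cl)cccc2s1)c1cc([N+](=O)[O-])ccc1Cl` returns 15000 nM as an actual number. On these numbers compound 1 stands at the limit of > 25000 nM in this assay, at which 2 of the 3 values shown sit, and has no exact value. Compound 4 `O=C(Nc1ccc(F)c(-c2nc3ccccc3s2)c1)c1cc([N+](=O)[O-])ccc1Cl` carries 1,3-benzothiazol-2-yl in place of 1,3-benzoxazol-2-yl on an aromatic carbon ortho to a fluoro group (1,3-benzothiazol-2-yl in place of 1,3-benzoxazol-2-yl on an aromatic carbon). Among the compounds with values here, no measured pair shows this exchange, so no step beyond the scatter is expected in this assay for it. The estimated change is an at least 1.2-fold lower number from compound 1 to compound 4 (0.09 log units; that floor lies within the scatter) and is expected to stay within that scatter. The estimate for compound 4 is 20000 nM (expected range 9000 nM to 40000 nM).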

Compound 4, half-maximal effective concentration: > 25000 nM
Compound 4: a limit, no number; the forecaster's own chance of this, stated with the estimate: 60%; at least 1.2-fold (0.09 log units) between middle value and limit.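

Compound 1 and compound 4 each give only a limit of the assay in this assay, so no step can be read between them: the limit of > 25000 nM in this assay, at which 3 of the 4 values shown sit. The compounds shown leave open whether 1,3-benzothiazol-2-yl in place of 1,3-benzoxazol-2-yl changes the number at all.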